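The source may report more compounds than this note shows. Statements on the series, on what has been measured and on what is new or still open speak of the compounds shown alone.

Working notes on the series.

In a functional assay on cells for antagonist activity at C-C chemokine receptor type 4 (Homo sapiens), read by fluorescence and calcium flux, with stated times of 2.5 s and 45 s (on this read-out higher numbers stand for weaker inhibition and lower numbers for stronger inhibition), compound 1 `Cc1nn([C@H](C)c2ccc(Cl)cc2Cl)c2nc(N3CC[C@H](N4CCC[C@H]4C(N)=O)[C@H](C)C3)cnc12` gives 170 nM. Of the three numbers in hand it is the second highest: compound 3 `C[C@@H]1CC(c2cnc3c(C#N)nn([C@H](C)c4ccc(Cl)cc4Cl)c3n2)=CC[C@@H]1N1CCC[C@H]1C` gives 34 nM, a lower number that lies beyond the scatter, while compound 2 `CC(c1ccc(Cl)cc1Cl)n1ncc2ncc(N3CCC(N4CCCCC4)CC3)nc21` gives 2580 nM, a higher number that also lies beyond the scatter. Going by the values given here, no single-change pair joins the three measured compounds, so no stepwise comparison is available among them.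

Compound 4 `Cc1nn([C@H](C)c2ccc(Cl)cc2Cl)c2nc(N3CC[C@H](N4CCCCCC4)[C@H](C)C3)cnc12` has not yet been tested in this assay. It differs from compound 1 in one place: azepan-1-yl in place of 2-carbamoylpyrrolidin-1-yl on a saturated ring carbon. The ring that enters carries no hydrogen-bond donor and one acceptor, whereas the ring that leaves carries one donor and two acceptors. Among the compounds with values here, no measured pair shows this particular exchange, so the expectation rests only on the number for compound 1 and the spread of the series. Given that compound 1 gives 170 nM, the exchange is expected to move the number modestly upward, toward weaker inhibition, as the step of a 2.6-fold higher number from compound 1 to compound 4 (0.42 log units; beyond the scatter) shows. Compound 4 is accordingly estimated at 450 nM, within a range from 120 nM to 1700 nM.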

Compound 4, half-maximal inhibitory concentration: 23 nM
Beside the measured number, compound 4's estimate is 20-fold (1.29 log units) above it; the measured number lies below the stated range.
By their numbers in this assay, from the lowest: compounds 4 and 3 (each within the scatter of the next); then compound 1; then compound 2.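

The step of a 7.4-fold lower number from compound 1 to compound 4 (0.87 log units; beyond the scatter) in this assay comes from exchanging the 2-carbamoylpyrrolidin-1-yl group for azepan-1-yl; the carbon that carries it is a saturated ring carbon, next to the ring atom that bears a methyl group. At this position, then, the hydrogen-bond donor, the carbonyl and the defined stereocentre of the group that leaves are not required for a number this low. Going by these compounds alone, this is also the first single-change pair, and it shows that this position can shift the number beyond the scatter. Nothing in hand accounts for the size of this step.

The pair leaves open how much of the step belongs to the larger ring and how much to the loss of the carbamoyl group, which unsubstituted pyrrolidin-1-yl at this carbon would separate. Going by these compounds, a carboxylic acid or a dimethylamino group at the same place also remains open.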